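A few compounds are considered here, and "the series" means these few. Any claim that something is new, unique, unknown or untested is made for them only; others in the source may bear on it.

Compound 1 `COC[C@]12C[C@H]1[C@@](C)(c1cc(NC(=O)c3ccc(Cl)cn3)cc(F)c1F)N=C(N)S2` is the starting point for this step. In an ADME assay on LLC-PK1 cells (Sus scrofa) for permeability (a lower number here means that the compound crosses the layer more slowly, a higher number that the compound crosses the layer faster), compound 1 gives 13 10^-6 cm/s and holds the lower of the two numbers in hand, while compound 2 `CNC(=O)[C@]12C[C@H]1[C@@](C)(c1cc(NC(=O)c3ccc(Cl)cn3)cc(F)c1F)N=C(N)S2` gives 29 10^-6 cm/s on the same scale. Compound 3 `COC[C@]12C[C@H]1[C@@](C)(c1cc(NC(=O)c3ccc(OCC(F)(F)F)cn3)cc(F)c1F)N=C(N)S2` carries the change 2,2,2-trifluoroethoxy in place of chloro on an aromatic carbon in the form of 2,2,2-trifluoroethoxy in place of chloro on an aromatic carbon, two atoms from the ring nitrogen and para to a large group. For the measured compounds named here, the only measured step is a 2.2-fold higher number from compound 1 to compound 2 (0.35 log units; beyond the scatter) and it was modest, but it places methylcarbamoyl in place of methoxymethyl on a saturated ring carbon, not on the aromatic carbon changed here. Going by the values given here, no measured step covers this exchange, so the data give no direction for it. With the modest 2.2-fold higher number from compound 1 to compound 2 (0.35 log units; beyond the scatter) as the only yardstick of size, no step beyond the scatter is expected in this assay for this change. The estimated step of a 1.1-fold lower number from compound 1 to compound 3 (0.03 log units; within the scatter) is expected to stay within the scatter. For compound 3 the estimate is 12 10^-6 cm/s with an expected range from 6 10^-6 cm/s to 22 10^-6 cm/s on this read-out.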

Compound 3, apparent permeability: 18 10^-6 cm/s
For compound 3 the middle estimate is 1.5-fold (0.18 log units) below the measured one, within the range that was stated.
By their numbers in this assay, from the lowest: compounds 1, 3 and 2 (each within the scatter of the next, the first and the last beyond it).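

In this assay, for the compounds shown here, the exchange of chloro for 2,2,2-trifluoroethoxy gives a 1.4-fold higher number from compound 1 to compound 3 (0.14 log units; within the scatter) and is the first measured step at this aromatic carbon, two atoms from the ring nitrogen and para to a large group. Going by these compounds alone, the read-out thus stays within the scatter at this position while the substituent goes from 1 heavy atom to 6 heavy atoms and gains 1 hydrogen-bond acceptor, so on the core of compound 1 this change gives no step that can be told from repeat measurements. No measurement at hand explains why this exchange leaves the read-out within the scatter.

On these data alone, whether this holds for other groups at the same aromatic carbon remains open, for example an amine, a carboxylic acid or a longer alkoxy chain, any of which could give a step beyond the scatter. As far as these compounds go, it also remains open whether 2,2,2-trifluoroethoxy in place of chloro gives a similar step on the core of compound 2, which carries methylcarbamoyl on the saturated ring carbon in place of methoxymethyl.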